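Swapping a Trifluoromethyl for a Pyrimidine Ring

This account rests on a few compounds, and the source may have more. Where it says the series, first, only, none or still open, it means among the compounds named here.

The measured compounds, all tested in an assay for inhibition of protein disulfide-isomerase (Homo sapiens), with a stated time of 1 h; a lower number here means a stronger inhibitor, a higher number a weaker inhibitor:
- compound 1, `Oc1ccc2[nH]ncc2c1C(c1ccc(-n2cccc2)cc1)N1CCCCC1`, gives 290 nM
- compound 2, `Oc1ccc2cnccc2c1C(c1ccc(F)cc1)N1CCCCC1`, gives only a limit, > 100000 nM, which is the limit of > 100000 nM in this assay, at which 1 of the 3 values shown sits.
- compound 3, `Oc1ccc2[nH]ncc2c1C(c1ccc(C(F)(F)F)cc1)N1CCCCC1`, gives 710 nM

Among the two real numbers, compound 3 has the higher one, and the only step that connects it to another measured compound is a 2.4-fold higher number from compound 1 to compound 3 (0.39 log units; beyond the scatter). Among the measured compounds shown here, compound 2 carries a different core and shows only a limit, so it offers no step here.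

The unmeasured compound 4, `Oc1ccc2[nH]ncc2c1C(c1ccc(-c2cncnc2)cc1)N1CCCCC1`, differs from compound 3 in one place: pyrimidin-5-yl in place of trifluoromethyl on an aromatic carbon. This is the mirror of the measured step, in which a ring on that same aromatic carbon was exchanged for trifluoromethyl and the number rose modestly. For the measured compounds named here, putting an aromatic ring back in that position is therefore expected to move the number in this assay modestly downward, though pyrimidin-5-yl is not pyrrol-1-yl and the single comparison gives only a rough guide.

On that basis compound 4 is estimated at 350 nM, with a plausible range from 120 nM to 1000 nM, an expected step of a 2.0-fold lower number from compound 3 to compound 4 (0.31 log units; beyond the scatter).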

Compound 4, half-maximal inhibitory concentration: 830 nM
Compound 4: middle estimate off by 2.4-fold (0.38 log units), on the low side; the range from low to high includes it.
By their numbers in this assay, from the lowest: compound 1; then compounds 3 and 4 (each within the scatter of the next). At a limit, above all of these: compound 2.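

In this assay, the exchange on this aromatic carbon gives a 1.2-fold higher number from compound 3 to compound 4 (0.07 log units; within the scatter), so a group with no ring and a group with a six-membered aromatic ring cannot be told apart here by this read-out. An aromatic ring at this place is therefore not enough on its own to match compound 1: changing 1H-pyrrol-1-yl to pyrimidin-5-yl gives a 2.9-fold higher number from compound 1 to compound 4 (0.46 log units; beyond the scatter), which shows that, for these two rings, the identity of the ring matters and not merely its presence. Nothing among the data shown explains why these two rings differ.

As far as these compounds go, it remains open whether a plain phenyl ring, an amine or a carboxylic acid at this place would fall nearer compound 1 or nearer compounds 3 and 4, and so whether the lower number of compound 1 reflects something particular to 1H-pyrrol-1-yl. Compound 2 cannot help with this, since it differs in both its core and its group on this aromatic carbon, and its value is only a limit.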